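Replacing 3,4-Dimethylphenyl with 4-Bromophenyl on the Amine Nitrogen

This account rests on a few compounds, and the source may have more. Where it says the series, first, only, none or still open, it means among the compounds named here.

Compound 1 `Cc1ccc(NC2=CC(=O)c3nc4n(c3C2=O)[C@H]2OC[C@@H](O)[C@H]2OC4)cc1C` gives 2820 nM in a functional assay on ECa-109 cells for inhibition, with ECa-109 cell line (Homo sapiens) as the target, read by sulforhodamine B assay; a higher number here means a weaker inhibitor, a lower number a stronger inhibitor. Compound 2 `Cc1ccc(NC2=CC(=O)c3c(nc4n3[C@H]3OC[C@@H](O)[C@H]3OC4)C2=O)cc1C` gives 4090 nM in this assay. Compound 3 `O=C1C=C(NCc2ccccc2)C(=O)c2c1nc1n2[C@H]2OC[C@@H](O)[C@H]2OC1` sits at the limit > 8000 nM in this assay, a limit rather than a number.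

Compound 2 stands highest of the two numbers, with compound 1 nearest and within the scatter. Compound 4 `O=C1C(Nc2ccc(Br)cc2)=CC(=O)c2c1nc1n2[C@H]2OC[C@@H](O)[C@H]2OC1` differs from compound 2 by 4-bromophenyl in place of 3,4-dimethylphenyl on an amine nitrogen. For the measured compounds named here, the only measured step, an at least 2.8-fold higher number from compound 1 to compound 3 (0.45 log units; beyond the scatter), swaps the aryl group for benzyl and so bears only loosely on an aryl-to-aryl exchange; its size shows that changes on this amine nitrogen can reach the limit (the limit of > 8000 nM in this assay, at which 1 of the 3 values shown sits). For compound 4 a step of a 1.2-fold lower number from compound 2 to compound 4 (0.07 log units; within the scatter) is expected, likely within the scatter. Compound 4 is estimated at 3500 nM, between 1500 nM and 8000 nM.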

Compound 4, half-maximal inhibitory concentration: 1980 nM
Estimate against measurement, compound 4: 1.8-fold (0.25 log units) above; the range from low to high includes it.
By their numbers in this assay, from the lowest: compounds 4, 1 and 2 (each within the scatter of the next, the first and the last beyond it). At a limit, above all of these: compound 3.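

In this assay, the exchange on this amine nitrogen gives a 2.1-fold lower number from compound 2 to compound 4 (0.32 log units; beyond the scatter), the only aryl-to-aryl change shown. On the core of compound 2, then, the substituents on the phenyl ring alone can move the value, whereas the earlier step replaced the whole aryl group with benzyl. Nothing shown gives a cause for this step.

As far as these compounds go, it remains open whether the bromine or the loss of the two methyl groups accounts for the step, which a 4-methylphenyl or 4-chlorophenyl group would help separate. From the compounds shown here alone, whether 4-bromophenyl acts the same way on the core of compound 1 is also open.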